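From acetyl to phenyl on the aromatic ring

The source may report more compounds than this note shows. Statements on the series, on what has been measured and on what is new or still open speak of the compounds shown alone.

Among the measured compounds shown here, in a functional assay on NCI-H460 cells (Homo sapiens) for cytotoxicity, read by MTT assay, with a stated time of 48 h (a lower number here means a stronger inhibitor, a higher number a weaker inhibitor), compound 3 `C=C1C(=O)O[C@H]2CC3=C[C@H](C/C(C)=C/[C@@H](OC(=O)c4ccc(C(C)=O)cc4)[C@H]12)OC3=O` gives 2200 nM, the only actual number in this small series. Compound 1 `C=C1C(=O)O[C@H]2CC3=C[C@H](C/C(C)=C/[C@@H](OC(=O)c4ccc(C(F)(F)F)cc4)[C@H]12)OC3=O` carries trifluoromethyl in place of the acetyl and gives > 10000 nM, which is a limit of the assay and not a number. Compound 2 `C=C1C(=O)O[C@H]2CC3=C[C@H](C/C(C)=C/[C@@H](OC(=O)c4ccc([N+](=O)[O-])cc4)[C@H]12)OC3=O` carries nitro at that same place and gives > 10000 nM, again a limit and not a number. The series therefore has two compounds resting at the limit of > 10000 nM in this assay, at which 2 of the 3 values shown sit.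

Compound 4 `C=C1C(=O)O[C@H]2CC3=C[C@H](C/C(C)=C/[C@@H](OC(=O)c4ccc(-c5ccccc5)cc4)[C@H]12)OC3=O` keeps the shared core and puts phenyl in place of the acetyl of compound 3: phenyl in place of acetyl on an aromatic carbon.

For the measured compounds named here, two measured steps bear on this change: an at least 4.5-fold lower number from compound 1 to compound 3 (0.65 log units; beyond the scatter) and an at least 4.5-fold lower number from compound 2 to compound 3 (0.65 log units; beyond the scatter). Both arrive at acetyl, so among these three compounds, having another group in its place goes with a higher number. Neither step brings in a ring, however, so they give the likely direction better than the size.

The expected change in this assay is modest and towards a higher number, with an estimated step of a 2.3-fold higher number from compound 3 to compound 4 (0.36 log units; beyond the scatter). For compound 4 the estimated value is 5000 nM, with an expected range from 1500 nM to 10000 nM.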

Compound 4, half-maximal inhibitory concentration: 3500 nM
The estimate for compound 4 lay 1.4-fold (0.15 log units) above the measured number; low and high end bracket the measured number.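

In this assay the new result is a 1.6-fold higher number from compound 3 to compound 4 (0.20 log units; within the scatter), so at this place, para to a large group, phenyl and acetyl cannot be told apart. Acetyl's hydrogen-bond acceptor is therefore not needed for a readable value in this small series, as phenyl has 0 hydrogen-bond acceptors and still gives one, and the larger group with its aromatic ring is accepted here. Phenyl also stands clear of the other two groups, with an at least 2.8-fold lower number from compound 2 to compound 4 (0.45 log units; beyond the scatter) and an at least 2.8-fold lower number from compound 1 to compound 4 (0.45 log units; beyond the scatter), so two groups now give real numbers while nitro and trifluoromethyl do not: the limit of > 10000 nM in this assay, at which 2 of the 4 values shown sit.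

Going by these compounds, what sets acetyl and phenyl apart from nitro and trifluoromethyl remains unexplained, and the true values of compound 1 and compound 2 remain unknown, as each is only a limit. On these data alone, it also remains open whether an amine, a carboxylic acid or a longer chain at this place would give a readable number in this assay, or whether it would join compound 1 and compound 2 at the limit.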